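Working notes: the step from compound 3 to compound 4

The source may report more compounds than this note shows. Statements on the series, on what has been measured and on what is new or still open speak of the compounds shown alone.

Compound 1 `CCOC(=O)N1CCC(=NNC(=O)c2ccc(Cl)cc2)CC1`: 59000 nM
Compound 2 `CCOC(=O)N1CCC(=NNC(=O)c2ccc(F)cc2)CC1`: 74800 nM
Compound 3 `CCOC(=O)N1CCC(=NNC(=O)c2ccc(C)cc2)CC1`: 75500 nM

All three values come from a functional assay, read by spectrophotometry, with a stated time of 2 h; a lower number here means a stronger inhibitor, a higher number a weaker inhibitor. Compound 3 cannot be separated from the other two on these numbers. The steps that reach it are a 1.3-fold higher number from compound 1 to compound 3 (0.11 log units; within the scatter) and a 1.0-fold higher number from compound 2 to compound 3 (0.00 log units; within the scatter). The remaining step, a 1.3-fold higher number from compound 1 to compound 2 (0.10 log units; within the scatter), is equally small. Chloro, fluoro and methyl thus give values that are indistinguishable in this small set.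

Compound 4 `CCOC(=O)N1CCC(=NNC(=O)c2ccc([N+](=O)[O-])cc2)CC1` has not yet been measured. It carries nitro in place of methyl on an aromatic carbon, para to a large group: nitro in place of methyl on an aromatic carbon.

All three measured steps are exchanges at this same place, so all three bear on the new change, though none of them involves nitro. The closest guide is the exchange away from methyl, a 1.3-fold higher number from compound 1 to compound 3 (0.11 log units; within the scatter), read in reverse, and it stays within the scatter. On that basis no step beyond the scatter is expected in this assay, and no direction can be argued with confidence. The expected change is a 1.2-fold lower number from compound 3 to compound 4 (0.07 log units; within the scatter). Within the data shown here, with no nitro compound measured so far, the range is kept wide. The estimated value for compound 4 is 65000 nM, with an expected range from 30000 nM to 130000 nM.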

Compound 4, half-maximal inhibitory concentration: 51700 nM
For compound 4 the middle estimate is 1.3-fold (0.10 log units) above the measured one, within the range that was stated.
By their numbers in this assay, from the lowest: compounds 4, 1, 2 and 3 (each within the scatter of the next).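

In this assay, nitro on an aromatic carbon, para to a large group, gives steps that all stay within the scatter (a 1.5-fold lower number from compound 3 to compound 4 (0.16 log units; within the scatter)), (a 1.4-fold lower number from compound 2 to compound 4 (0.16 log units; within the scatter)) and (a 1.1-fold lower number from compound 1 to compound 4 (0.06 log units; within the scatter)). The earlier compounds shown here covered only chloro, fluoro and methyl, whereas nitro brings more heavy atoms than methyl and hydrogen-bond acceptors where methyl has none, and still no step beyond the scatter appears at this position, so the four compounds remain unseparated on these numbers. No independent measurement is available that would tie these small steps to any property of the groups.

Still open is whether any group at this position can move the number beyond the scatter, for instance an amine, a carboxylic acid or a longer chain such as butyl, since the four groups shown give no handle on the direction of a change. Equally open, going by these compounds, is whether a change elsewhere on the shared core would give a larger step than any exchange at this aromatic carbon has so far.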